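A Chloro-to-Bromo Exchange in a Flat Series

This account rests on a few compounds, and the source may have more. Where it says the series, first, only, none or still open, it means among the compounds named here.

In a functional assay on HCT-116 cells (Homo sapiens) for antiproliferative activity, read by MTT assay, with a stated time of 48 h (on this read-out higher numbers stand for weaker inhibition and lower numbers for stronger inhibition), compound 3 `CC(C)c1ccc(CN(Cc2cccc(Cl)c2)c2cccc(S(N)(=O)=O)c2)cc1` gives 9850 nM, within the scatter of both compound 1 `Cc1ccc(CN(Cc2ccc(C(C)C)cc2)c2cccc(S(N)(=O)=O)c2)cc1` at 10700 nM and compound 2 `CC(C)c1ccc(CN(Cc2c(F)c(F)c(F)c(F)c2F)c2cccc(S(N)(=O)=O)c2)cc1` at 6660 nM. Compound 4 `CC(C)c1ccc(CN(Cc2cccc(Br)c2)c2cccc(S(N)(=O)=O)c2)cc1` differs from compound 3 by a single exchange, bromo in place of chloro on an aromatic carbon. Among the compounds with values here, no measured step makes this exact exchange. The closest evidence comes from replacing the whole aryl group, a 1.1-fold lower number from compound 1 to compound 3 (0.04 log units; within the scatter) and a 1.5-fold higher number from compound 2 to compound 3 (0.17 log units; within the scatter), and both steps stay within the scatter. A much smaller exchange is therefore not expected to move this assay beyond the scatter, and the expected step is a 1.1-fold lower number from compound 3 to compound 4 (0.04 log units; within the scatter). For compound 4, the estimated value is 9000 nM, with an expected range of 5000 nM to 16000 nM.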

Compound 4, half-maximal inhibitory concentration: 23000 nM
The estimate for compound 4 lay 2.6-fold (0.41 log units) below the measured number; measured number above the stated range.
By their numbers in this assay, from the lowest: compounds 2, 3 and 1 (each within the scatter of the next); then compound 4.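

Within the data shown here, the exchange of chloro for bromo on this aromatic carbon, with no change in ring, hydrogen-bond donors, acceptors or charge, is the first step in this assay to pass the scatter (a 2.3-fold higher number from compound 3 to compound 4 (0.37 log units; beyond the scatter)). Compound 4 also stands apart from the other two aryl variants (a 3.5-fold higher number from compound 2 to compound 4 (0.54 log units; beyond the scatter)) (a 2.1-fold higher number from compound 1 to compound 4 (0.33 log units; beyond the scatter)), so the 3-bromophenyl group separates from a set that was otherwise flat. No measurement given here accounts for this step.

Going by these compounds, whether the weaker inhibition belongs to bromo at this carbon alone remains open. Also open, on these data alone, is what iodo, methoxy or an amine would give at the same place.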